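A few compounds are considered here, and "the series" means these few. Any claim that something is new, unique, unknown or untested is made for them only; others in the source may bear on it.

Measured compounds in an ADME assay on MT4 cells (Homo sapiens) for cytotoxicity; a higher number here means that more compound is tolerated, a lower number that less compound is tolerated:
- compound 1, `O=C(Nc1ccccn1)c1nc[nH]c1C(=O)O`, gives > 20000 nM, which is a limit of the assay and not a number.
- compound 2, `O=C(Nc1ccccn1)c1nc[nH]c1C(=O)N1CCC(O)CC1`, gives > 20000 nM, again a limit of the assay.
- compound 3, `O=C(Nc1ccccn1)c1nc[nH]c1C(=O)N1CCNCC1`, gives > 20000 nM, again a limit of the assay.

All three readings sit at the limit of > 20000 nM in this assay, at which 3 of the 3 values shown sit, so none of them is a number that can be compared with another. The step from compound 1 to compound 2 is a step that the two limits leave unreadable from compound 1 to compound 2, the step from compound 1 to compound 3 is a step that the two limits leave unreadable from compound 1 to compound 3, and the step from compound 2 to compound 3 is a step that the two limits leave unreadable from compound 2 to compound 3. Compound 3 therefore stands only at a limit, and the two other values shown are limits as well.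

Compound 4, `O=C(Nc1ccccc1O)c1nc[nH]c1C(=O)N1CCNCC1`, is not yet measured. It differs from compound 3 in one place: 2-hydroxyphenyl in place of pyridin-2-yl on an amide-type nitrogen. Among the measured compounds shown here, none of the measured steps alters this part of the molecule, and none of them has a readable size, so no measured step bears directly on this change. For the measured compounds named here, what is known is only that the three measured compounds share the same limit. Compound 4 is therefore expected to come out at that limit in this assay as well. The expected step is a step that the limit leaves unreadable from compound 3 to compound 4, none beyond the scatter. Compound 4 is estimated at 30000 nM, with a range from 10000 nM to 100000 nM.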

Compound 4, half-maximal cytotoxic concentration: > 20000 nM
Compound 4: only a limit was reported (the forecaster's own chance of this, stated with the estimate: 80%); the middle value lies beyond the limit too.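

In this assay compound 4 gives > 20000 nM, a limit and not a number, so the step from compound 3 to compound 4 cannot be read. All readings share one ceiling: the limit of > 20000 nM in this assay, at which 4 of the 4 values shown sit.

The compounds shown leave open at what concentration any of them harms these cells, and whether any of these changes shifts it.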